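Homologated hydroxycyclohexyl analogue of an aminopyridine nitrile

The source may hold more compounds than are shown below. What is called first, only, known or untested is meant among the compounds shown, and "the series" means these compounds.

Measured compounds:
compound 1 `N#Cc1cnc(NCc2cnccc2C(F)(F)F)cc1N[C@H]1C[C@H](O)C1` gives 900 nM in an assay on isolated protein for inhibition of protein kinase C theta type (Homo sapiens), read by TR-FRET, with a stated time of 2 h; a lower number here means a stronger inhibitor, a higher number a weaker inhibitor;
compound 2 `N#Cc1cnc(NCc2cnccc2C(F)(F)F)cc1NC[C@H]1C[C@H](O)C1` gives 700 nM in this assay;
compound 3 `CO[C@H]1CC[C@@H](Nc2cc(NCc3cnccc3C(F)(F)F)ncc2C#N)CC1` gives 58 nM in this assay.

Compound 3 stands lowest of the three numbers, its nearest neighbour being compound 2 and its furthest compound 1, both beyond the scatter. The unmeasured compound 4 `N#Cc1cnc(NCc2cnccc2C(F)(F)F)cc1NC[C@H]1CC[C@H](O)CC1` is reached by the change ((4-hydroxycyclohexyl)methyl in place of 4-methoxycyclohexyl on a nitrogen on an aromatic ring). Two of the measured steps bear on this. The step of a 16-fold lower number from compound 1 to compound 3 (1.19 log units; beyond the scatter) and the step of a 12-fold lower number from compound 2 to compound 3 (1.08 log units; beyond the scatter) show that going to the six-membered ring with a methoxy group brought a large drop in the number, and compound 4 keeps a six-membered ring. The step of a 1.3-fold lower number from compound 1 to compound 2 (0.11 log units; within the scatter) shows that inserting a methylene between the ring and the nitrogen made no difference beyond the scatter for the cyclobutyl pair. Among the measured compounds shown here, compound 4, however, also exchanges the methoxy for a hydroxy, and no measured pair isolates that change on the six-membered ring. Compound 4 is therefore expected to lie somewhat above compound 3, with a step of a 3.4-fold higher number from compound 3 to compound 4 (0.54 log units; beyond the scatter) considered likely. The estimate for compound 4 in this assay is 200 nM, within a range from 60 nM to 700 nM.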

Compound 4, half-maximal inhibitory concentration: 50 nM
Estimate against measurement, compound 4: 4.0-fold (0.60 log units) above; measured number below the stated range.
By their numbers in this assay, from the lowest: compounds 4 and 3 (each within the scatter of the next); then compounds 2 and 1 (each within the scatter of the next).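

The step of a 1.2-fold lower number from compound 3 to compound 4 (0.06 log units; within the scatter) shows that in this assay (4-hydroxycyclohexyl)methyl can take the place of 4-methoxycyclohexyl on this nitrogen with no change beyond the scatter, although the entering group brings a hydrogen-bond donor that the leaving group lacks. The large gain seen earlier therefore does not depend on the methoxy group: with the hydroxy group and the methylene both kept, the ring change alone gives a 14-fold lower number from compound 2 to compound 4 (1.15 log units; beyond the scatter), and the wider change gives an 18-fold lower number from compound 1 to compound 4 (1.26 log units; beyond the scatter), so among these four compounds both six-membered examples, compound 3 and compound 4, sit well under both cyclobutyl examples, compound 1 and compound 2, with none going against this. No measurement shown here accounts for this preference for the six-membered ring.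

Within the pair of compound 3 and compound 4, the added methylene and the exchange of methoxy for hydroxy change together, so what each contributes on the six-membered ring stays open. Also open, going by these compounds, is how an amine or a carboxylic acid in place of the hydroxy group, or a longer chain to the nitrogen, would read in this assay.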